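This account rests on a few compounds, and the source may have more. Where it says the series, first, only, none or still open, it means among the compounds named here.

Compound 1, `O=S(=O)(Nc1ccc2oc(-c3ccccc3)nc2c1)c1ccccc1F`, gives in an assay on isolated protein for inhibition of malate dehydrogenase, mitochondrial (Sus scrofa), with stated times of 45 min and 30 min (a lower number here means a stronger inhibitor, a higher number a weaker inhibitor), only a limit, > 63000 nM.
Compound 2, `COc1ccc(S(=O)(=O)Nc2ccc3oc(-c4ccccc4)nc3c2)cc1`, gives in this assay only a limit, > 63000 nM.
Compound 3, `COc1ccc(Cl)cc1S(=O)(=O)Nc1ccc2oc(-c3ccccc3)nc2c1`, gives in this assay only a limit, > 63000 nM.

Compound 3 therefore stands at the upper edge of what this assay can report, and the two other values shown stand at the same edge. None of the three steps among the measured compounds can be read: a step that the two limits leave unreadable from compound 1 to compound 2, a step that the two limits leave unreadable from compound 1 to compound 3 and a step that the two limits leave unreadable from compound 2 to compound 3. Going by the values given here, the one piece of evidence on these steps is the limit of > 63000 nM in this assay, at which 3 of the 3 values shown sit.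

Compound 4, `O=S(=O)(Nc1ccc2oc(-c3ccccc3)nc2c1)c1ccc(Cl)c(Cl)c1`, differs from compound 3 in one place: 3,4-dichlorophenyl in place of 5-chloro-2-methoxyphenyl on a sulfonyl sulfur. All three measured steps bear on this change, since each of them also exchanges the aryl group on the sulfonyl sulfur, and each was left unreadable by the limits. Among the compounds with values here, no measured step gives a direction for the change from compound 3 to compound 4, so compound 4 is expected to remain at the limit, and a step that the limit leaves unreadable from compound 3 to compound 4 is the expected step, meaning none beyond the scatter. Compound 4 is therefore estimated at 100000 nM in this assay, within a range from 40000 nM to 300000 nM.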

Compound 4, half-maximal inhibitory concentration: > 63000 nM
Compound 4: a limit, no number; the forecaster's own chance of this, stated with the estimate: 80%; the middle value does not contradict the limit.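

Compound 4 gives only a limit in this assay, as do compound 1, compound 2 and compound 3, so none of the steps to compound 4 can be read: the limit of > 63000 nM in this assay, at which 4 of the 4 values shown sit.

The compounds shown leave open how far apart these four compounds lie in this assay and whether the aryl group on the sulfonyl sulfur matters at all.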